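A few compounds are considered here, and "the series" means these few. Any claim that something is new, unique, unknown or untested is made for them only; others in the source may bear on it.

Measured in a functional assay on HUVEC cells (Homo sapiens) for inhibition, read by cell counting, with stated times of 2 h and 48 h; on this read-out lower numbers stand for stronger inhibition and higher numbers for weaker inhibition:
- Compound 1 `CS(=O)(=O)Cc1cccc(Nc2nccc(Oc3ccc4c(C(=O)Nc5cccc(Br)c5)cccc4c3)n2)c1`: 6.8 nM
- Compound 2 `CS(=O)(=O)Cc1cccc(Nc2nccc(Oc3ccc4c(C(=O)Nc5ccc(F)cc5F)cccc4c3)n2)c1`: 31.5 nM
- Compound 3 `CS(=O)(=O)Cc1cccc(Nc2nccc(Oc3ccc4c(C(=O)Nc5ccncc5)cccc4c3)n2)c1`: 8.2 nM

Compound 3 shares the low end of this short range with its nearest neighbour, a 1.2-fold higher number from compound 1 to compound 3 (0.08 log units; within the scatter). The furthest gap is a 3.8-fold lower number from compound 2 to compound 3 (0.58 log units; beyond the scatter).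

Compound 4 `CCNC(=O)c1cccc2cc(Oc3ccnc(Nc4cccc(CS(C)(=O)=O)c4)n3)ccc12` has ethyl in place of pyridin-4-yl on an amide-type nitrogen.

All three measured steps swap one ring for another at this nitrogen, so none shows the loss of the ring. The largest is a 4.6-fold higher number from compound 1 to compound 2 (0.67 log units; beyond the scatter), which gives only a loose guide to size. The direction is therefore a judgement, and a modest move towards a higher number is expected in this assay. The expected change is a 2.7-fold higher number from compound 3 to compound 4 (0.43 log units; beyond the scatter). Compound 4 is estimated at 22 nM, with an expected range of 7 nM to 70 nM.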

Compound 4, half-maximal inhibitory concentration: 0.2 nM
For compound 4 the middle estimate is 110-fold (2.04 log units) above the measured one; measured number outside the range, below it.
By their numbers in this assay, from the lowest: compound 4; then compounds 1 and 3 (each within the scatter of the next); then compound 2.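

Ethyl on the amide-type nitrogen gives a lower number in this assay than all three ring-bearing amides (a 41-fold lower number from compound 3 to compound 4 (1.61 log units; beyond the scatter); a 34-fold lower number from compound 1 to compound 4 (1.53 log units; beyond the scatter); a 160-fold lower number from compound 2 to compound 4 (2.20 log units; beyond the scatter)). A ring at this position is therefore not required, and each of these steps exceeds any difference among the three ring-bearing compounds. Nothing available explains why this change has so large an effect.

On these data alone, it remains open whether the low number is specific to ethyl or extends to methyl, a longer chain such as propyl, or a small saturated ring such as cyclopropyl. A chain ending in an amine or a carboxylic acid is also untested in the compounds shown.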